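Substituent on the terminal ring amine: compound 2 to compound 3

The source may hold more compounds than are shown below. What is called first, only, known or untested is meant among the compounds shown, and "the series" means these compounds.

Measured so far:
compound 1 `CCN(CC)c1ccc2cc(C(=O)c3ccc(N4CCN(C(=O)CN5CCNCC5)CC4)cc3)oc2c1` – 5340 nM
compound 2 `C#CCN1CCN(CC(=O)N2CCN(c3ccc(C(=O)c4cc5ccc(N(CC)CC)cc5o4)cc3)CC2)CC1` – > 40000 nM

In a functional assay on MCF7 cells (Homo sapiens) for cytotoxicity, read by MTT assay, with a stated time of 48 h (on this read-out higher numbers stand for weaker inhibition and lower numbers for stronger inhibition), compound 1 gives 5340 nM. Compound 2 reaches only the assay limit, > 40000 nM, so no number is known for it. Within the data shown here, the single measured step, an at least 7.4-fold higher number from compound 1 to compound 2 (0.87 log units; beyond the scatter), runs into that limit (the limit of > 40000 nM in this assay, at which 1 of the 2 values shown sits). Compound 3 `CCN(CC)c1ccc2cc(C(=O)c3ccc(N4CCN(C(=O)CN5CCN(Cc6ccc(/C=C/C(=O)OC)cc6)CC5)CC4)cc3)oc2c1` differs from compound 2 by 4-(2-(methoxycarbonyl)ethenyl)phenyl in place of ethynyl on a saturated chain carbon bound to an amine nitrogen in a ring. Among the measured compounds shown here, no measured step covers this change, and the starting point is itself a limit, so the expectation for this assay is a number near that limit with a wide range. Compound 3 is expected at 40000 nM (10000 nM to 150000 nM), a step of a number no higher from compound 2 to compound 3 (the limit leaves the size open), with a fair chance that only a limit is reported again.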

Compound 3, half-maximal inhibitory concentration: 8730 nM
Compound 3: middle estimate off by 4.6-fold (0.66 log units), on the high side; measured number below the stated range.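

In this assay, substitution on the terminal ring amine does not by itself drive the read-out to the limit: 4-(2-(methoxycarbonyl)ethenyl)phenyl in place of ethynyl gives an at least 4.5-fold lower number from compound 2 to compound 3 (0.66 log units; beyond the scatter). On these data alone, compound 2 carries a limit and not a number, and the size of this step stays open: the limit of > 40000 nM in this assay, at which 1 of the 3 values shown sits. Compound 3 gives 8730 nM, and compound 1, with hydrogen on that nitrogen, gives 5340 nM.

Which part of the entering group matters stays open: the phenyl ring, the ethenyl link or the methyl ester. A carboxylic acid in place of the ester, or a plain benzyl group on the same nitrogen, would separate these.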